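A few compounds are considered here, and "the series" means these few. Any claim that something is new, unique, unknown or untested is made for them only; others in the source may bear on it.

Measured in an ADME assay on CCRF-HSB-2 cells (Homo sapiens) for cytotoxicity, with a stated time of 7 days; a lower number here means that less compound is tolerated, a higher number that more compound is tolerated:
- compound 1 `Nc1nc(NC2CCCCC2)c2ncn(/C=C3/CC3(CO)CO)c2n1` gives > 20000 nM, a limit of the assay.
- compound 2 `CCCNc1nc(N)nc2c1ncn2/C=C1/CC1(CO)CO` gives > 20000 nM, a limit of the assay.
- compound 3 `CCCOc1nc(N)nc2c1ncn2/C=C1/CC1(CO)CO` gives > 20000 nM, a limit of the assay.

All three values sit at the limit of > 20000 nM in this assay, at which 3 of the 3 values shown sit, so compound 3 cannot be ranked against compound 1 or compound 2 in this assay. Compound 4 `Nc1nc(N2CCCC2)c2ncn(/C=C3/CC3(CO)CO)c2n1` differs from compound 3 in one place: pyrrolidin-1-yl in place of propoxy on an aromatic carbon. The two measured steps that reach compound 3, a step that the two limits leave unreadable from compound 1 to compound 3 and a step that the two limits leave unreadable from compound 2 to compound 3, both run between limits, so their sizes are not readable and give no scale for a change on this aromatic carbon. No step beyond the scatter is expected for compound 4, and its value is most likely again a limit. The estimate for compound 4 is 30000 nM, within 15000 nM to 100000 nM. This expected step is a step that the limit leaves unreadable from compound 3 to compound 4.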

Compound 4, half-maximal cytotoxic concentration: > 20000 nM
Compound 4: a limit, no number; the forecaster's own chance of this, stated with the estimate: 85%; the middle value lies beyond the limit too.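

Compound 4 gives a limit and not a number, like compound 1, compound 2 and compound 3, so no step among them can be read: the limit of > 20000 nM in this assay, at which 4 of the 4 values shown sit.

The concentration at which any of these compounds harms the cells in this assay stays open.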